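A pyridine swap on the shared core

The source may report more compounds than this note shows. Statements on the series, on what has been measured and on what is new or still open speak of the compounds shown alone.

Of the compounds shown here, three with the shared core have been measured in an assay on T-REx-293 cells for inhibition of potassium channel subfamily T member 1 (Homo sapiens), read by patch clamp; on this read-out lower numbers stand for stronger inhibition and higher numbers for weaker inhibition. Compound 1 `CCc1cc(C(=O)N[C@@H](C)c2nc(-c3cccc(C)c3)no2)n(C)n1` gives 335 nM. Compound 2 `C[C@@H](c1nc(-c2cccc(F)c2)no1)N(C)C(=O)c1cc(C(F)(F)F)nn1C` gives 6490 nM. Compound 3 `Cc1cncc(-c2noc([C@H](C)NC(=O)c3cc(C(F)(F)F)nn3C)n2)c1` gives 1370 nM. Among these three numbers compound 3 stands second highest: compound 1 sits below it by a gap beyond the usual scatter, and compound 2 sits above it by a gap that is also beyond the scatter.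

Compound 4 `COCc1cc(-c2noc([C@H](C)NC(=O)c3cc(C(F)(F)F)nn3C)n2)ccn1` has not yet been measured. It differs from compound 3 in one place (2-(methoxymethyl)pyridin-4-yl in place of 5-methylpyridin-3-yl on an aromatic carbon). The group that leaves has seven heavy atoms and one hydrogen-bond acceptor; the group that enters has nine heavy atoms and two hydrogen-bond acceptors, and both are six-membered aromatic rings with one hetero atom.

Within the data shown here, no pair of measured compounds differs in exactly this way, so the size of the step cannot be read from the data. On this basis the step from compound 3 to compound 4 is expected to be small, at most modestly toward higher numbers, that is toward weaker inhibition, and it may well stay within the scatter: a 1.5-fold higher number from compound 3 to compound 4 (0.16 log units; within the scatter). Compound 4 is therefore estimated at 2000 nM, with a range from 700 nM to 6000 nM in this assay.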

Compound 4, half-maximal inhibitory concentration: 322 nM
Estimate against measurement, compound 4: 6.2-fold (0.79 log units) above; measured number outside the range, below it.
By their numbers in this assay, from the lowest: compounds 4 and 1 (each within the scatter of the next); then compound 3; then compound 2.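

In this assay, the group on the aromatic carbon between two ring nitrogen atoms proves able to move the number: putting 2-(methoxymethyl)pyridin-4-yl in place of 5-methylpyridin-3-yl gives a 4.3-fold lower number from compound 3 to compound 4 (0.63 log units; beyond the scatter), with the rest of the molecule unchanged. Among these compounds, this is the first step that can be read at one place, as no two of the earlier compounds differ in only one place, and it shows that this position accepts the larger pyridine group with stronger inhibition rather than weaker. No measurement shown here bears on what lies behind this step.

As far as these compounds go, what stays open is how much of the step belongs to the methoxymethyl group and how much to the shift from a pyridin-3-yl to a pyridin-4-yl attachment, as the two change together here. Also open, from the compounds shown here alone, is whether a plain 2-methylpyridin-4-yl, or a pyridin-4-yl carrying an aminomethyl or an ethoxymethyl group at that same ring carbon, would move the number in the same direction.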